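This account rests on a few compounds, and the source may have more. Where it says the series, first, only, none or still open, it means among the compounds named here.

Compound 1, `COC(=O)N[C@H](C(=O)NN(CCC[C@@](O)(Cc1ccccc1)C(=O)N[C@H]1c2ccccc2C[C@H]1O)Cc1ccc(F)cc1)C(C)(C)C`, gives > 10000 nM in an ADME assay on MT4 cells (Homo sapiens) for cytotoxicity; a higher number here means that more compound is tolerated, a lower number that less compound is tolerated.
Compound 2, `COC(=O)N[C@H](C(=O)NN(CCC[C@@](O)(Cc1ccccc1)C(=O)N[C@H]1c2ccccc2C[C@H]1O)Cc1ccc(-c2nccs2)cc1)C(C)(C)C`, gives > 10000 nM in this assay.
Compound 3, `COC(=O)N[C@H](C(=O)NN(CCC[C@@](O)(Cc1ccccc1)C(=O)N[C@H]1c2ccccc2C[C@H]1O)Cc1ccc(OCc2cnc(Cl)s2)cc1)C(C)(C)C`, gives > 10000 nM in this assay.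

Each of these three values is a limit of this assay rather than a number. Compound 1 therefore sits at the limit of > 10000 nM in this assay, at which 3 of the 3 values shown sit, and nothing more can be said of how it ranks. Compound 4, `COC(=O)N[C@H](C(=O)NN(CCC[C@@](O)(Cc1ccccc1)C(=O)N[C@H]1c2ccccc2C[C@H]1O)Cc1ccc(-c2cccnc2)cc1)C(C)(C)C`, has not yet been measured in this assay. It differs from compound 1 in one place: pyridin-3-yl in place of fluoro on an aromatic carbon.

Among the compounds with values here, two measured steps touch the same position of the shared core: a step that the two limits leave unreadable from compound 1 to compound 2, and a step that the two limits leave unreadable from compound 1 to compound 3. Both start and end at the limit, so neither tells whether the value moved at all. The pair of compounds 2 and 3 is no more informative: a step that the two limits leave unreadable from compound 2 to compound 3.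

With every measured value at the limit, the expectation for compound 4 is simply that this assay will again report a limit, so that a number no higher from compound 1 to compound 4 (the limit leaves the size open) stays unreadable. The estimate for compound 4 is therefore 10000 nM, within a range from 5000 nM to 30000 nM.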

Compound 4, half-maximal cytotoxic concentration: > 10000 nM
Compound 4: only a limit was reported; the forecaster's own chance of this, stated with the estimate: 80%; the middle value lies on the limit itself.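

Compound 4 gives > 10000 nM in this assay, which is a limit and not a number. Its steps to compound 1, compound 2 and compound 3 therefore cannot be read: the limit of > 10000 nM in this assay, at which 4 of the 4 values shown sit.

The compounds shown leave open where the true half-maximal cytotoxic concentration of each lies, and whether exchanging the group on the aromatic carbon changes it at all.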